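Aziridinylquinone side chains: from isopropyl to a carbamate chain

This account rests on a few compounds, and the source may have more. Where it says the series, first, only, none or still open, it means among the compounds named here.

Measured so far:
compound 1, `CC1=C(N2CC2)C(=O)C(COc2ccccc2)=C(N2CC2)C1=O`: 5.15
compound 2, `CC1=C(N2CC2)C(=O)C(C(C)C)=C(N2CC2)C1=O`: 5.6

In a functional assay on L1210 cells (Mus musculus), with a stated time of 12 days (on this read-out lower numbers stand for lower potency and higher numbers for higher potency (the scale is a negative logarithm)), compound 2 gives 5.6, the higher of the two numbers. In this assay compound 1 gives 5.15, a gap beyond the usual scatter. For the measured compounds named here, no two measured compounds differ in one place only, so no computed step is available and the two values can only be set side by side.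

Compound 3, `CC1=C(N2CC2)C(=O)C(CCCOC(N)=O)=C(N2CC2)C1=O`, is not yet measured in this assay. It differs from compound 2 as follows: a group of 7 heavy atoms (4 carbon, 1 nitrogen, 2 oxygen; no ring) in place of a group of 3 heavy atoms (3 carbon; no ring), on a double-bonded ring carbon. Going by the values given here, the measured pair gives no guide to a chain of this kind on the double-bonded ring carbon; the phenoxymethyl of compound 1 is the only other group seen there and it sits lower. The step from compound 2 to compound 3 is therefore expected to be small, a number 0.10 log units higher from compound 2 to compound 3 (within the scatter), within the scatter. For compound 3 the estimate in this assay is 5.7, with a range from 5.1 to 6.3.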

Compound 3, logarithm of the reciprocal of the active concentration, log(1/C): 6.18
The estimate for compound 3 lay 0.48 log units below the measured number; the measured number falls inside the stated range.
By their numbers in this assay, from the lowest: compound 1; then compound 2; then compound 3.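

At the double-bonded ring carbon, the isopropyl group is not the upper limit in this assay: the carbamate chain gives a gain over it (a number 0.58 log units higher from compound 2 to compound 3 (beyond the scatter)). Exchanging phenoxy for 2-(carbamoyloxy)ethyl on the saturated chain carbon gives a larger gain (a number 1.03 log units higher from compound 1 to compound 3 (beyond the scatter)), so what follows that chain carbon strongly affects the read-out. No measurement accompanying these numbers bears on the cause of either step.

The two steps do not separate the contribution of chain length from that of the carbamate, so a plain propyl or butyl chain remains the missing comparison. Also open, as far as these compounds go, is whether the gain persists with a chain ending in a hydroxyl group, an amine or a carboxylic acid.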